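The compounds below may be only part of what the source reports. "The series", "measured", "known", "first", "only" and "open" are said of these compounds alone.

Working notes on the series in a functional assay on T-24 cells (Homo sapiens) for antiproliferative activity (a lower number here means a stronger inhibitor, a higher number a weaker inhibitor), follow. Compound 3 `N=C(NO)N/N=C/c1cccc(C(=N)N)c1` gives 14100 nM here, the lowest of the two actual numbers in the set. Compound 1 `C/C(=N\N=C(N)N)c1cccc(C(=N)N)c1` gives 118000 nM as a higher number, a gap beyond the scatter. Compound 2 `CC/C(=N\N=C(N)N)c1cccc(C(=N)N)c1` gives > 152000 nM which is a limit of the assay and not a number.

The next change leads to compound 4 `CCCCNC(=N)N/N=C/c1cccc(C(=N)N)c1` with butyl in place of hydroxy on an amine nitrogen as the difference. Among the measured compounds shown here, the only measured step is an at least 1.2-fold higher number from compound 1 to compound 2 (0.10 log units; that floor lies within the scatter) and it concerns methyl in place of hydrogen on a saturated chain carbon bound to a carbon with a double bond to nitrogen. That step lies elsewhere on the molecule, so it offers no size for the present change. For the measured compounds named here, no measured compound carries butyl.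

Compound 3 with hydroxy gives 14100 nM and compound 1 without hydroxy gives 118000 nM in this assay so a moderately higher number is expected, though with little confidence given that these two compounds also differ elsewhere. The expected step is a 1.8-fold higher number from compound 3 to compound 4 (0.25 log units; within the scatter) on this estimate. Compound 4 is estimated at 25000 nM with an expected range from 5000 nM to 120000 nM in this assay for now.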

Compound 4, half-maximal inhibitory concentration: > 26800 nM
Compound 4: only a limit was reported (the forecaster's own chance of this, stated with the estimate: 15%); middle value at least 1.0-fold (0.03 log units) away from the limit.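

In this assay compound 4 gives > 26800 nM, which is a limit of the assay and not a number. Among the compounds shown here, this is the first reading at this amine nitrogen, and swapping hydroxy for butyl gives an at least 1.9-fold higher number from compound 3 to compound 4 (0.27 log units; that floor lies within the scatter), so only a floor on the step is available, and that floor does not by itself separate the two groups. For the compounds shown here, what the earlier compounds did not show is the direction at this position: the limit leaves no room for a number lower than that of compound 3, so butyl brings no gain over hydroxy here, whereas the one earlier step concerned the saturated chain carbon and said nothing about this nitrogen.

From the compounds shown here alone, the real size of the change stays open because only a limit stands for compound 4: the limit of > 26800 nM in this assay, at which 1 of the 4 values shown sits. Also open, going by these compounds, is how a methyl, a shorter chain such as ethyl, or a methoxy on the same amine nitrogen would read against compound 3, and so whether the hydroxy itself or merely the small size of the group goes with the lower number.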